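The source may report more compounds than this note shows. Statements on the series, on what has been measured and on what is new or still open speak of the compounds shown alone.

Compound 1 `CCOC(=O)C1=C(C)NC(=O)NC1c1ccc(SC)cc1` and compound 3 `CCOC(=O)C1=C(C)NC(=S)NC1c1ccc(SC)cc1` carry the same methylsulfanyl-bearing aryl ring; how their two cores differ is not broken down here. In a functional assay on U-251 cells (Homo sapiens) for inhibition, read by sulforhodamine B assay, with a stated time of 48 h (on this read-out higher numbers stand for weaker inhibition of growth and lower numbers for stronger inhibition of growth), compound 1 gives 8 ug/mL, and compound 3 gives 6 ug/mL, the two lying within the scatter of each other. Compound 2 `CCCc1ccc(C2NC(=S)NC(C)=C2C(=O)OCC)cc1` shares the core of compound 3 and differs from it by propyl in place of methylsulfanyl on an aromatic carbon. In this assay compound 2 gives 29.2 ug/mL, which amounts to a 4.9-fold higher number from compound 3 to compound 2 (0.69 log units; beyond the scatter). Compound 4 `CCCc1ccc(C2NC(=O)NC(C)=C2C(=O)OCC)cc1` shares the core of compound 1 and differs from it by propyl in place of methylsulfanyl on an aromatic carbon. Among the measured compounds shown here, the two changes read the same word for word in place and in groups, so the change on compound 1 is the same kind of change as that on compound 3, and it is the one change that occurs twice in the set. With a single measured example to go on, the expected step is a 4.5-fold higher number from compound 1 to compound 4 (0.65 log units; beyond the scatter) in this assay, beside the earlier one. That expectation rests only on a 4.9-fold higher number from compound 3 to compound 2 (0.69 log units; beyond the scatter). Compound 4 is accordingly estimated at 36 ug/mL, with a likely range from 15 ug/mL to 90 ug/mL.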

Compound 4, concentration for 50% growth inhibition: 35.4 ug/mL
Estimate against measurement, compound 4: 1.0-fold (0.01 log units) above, within the range that was stated.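

In this assay, propyl in place of methylsulfanyl on the aromatic carbon gives a 4.4-fold higher number from compound 1 to compound 4 (0.65 log units; beyond the scatter), so growth inhibition weakens on the core of compound 1 as it does on the core of compound 3, and the two steps agree: the same change on two cores in this assay, a 4.9-fold higher number (0.69 log units; beyond the scatter) from compound 3 to compound 2 and a 4.4-fold higher number (0.65 log units; beyond the scatter) from compound 1 to compound 4, 1.1-fold (0.04 log units) apart, within the scatter of two such steps. For these two cores, the change can therefore be carried from one to the other with its direction and size preserved. Among the compounds shown here, this rests on only two matched pairs, one exchange of groups and one cell line, so it does not show that the step would hold on a further core or with other groups, and it gives no explanation for the step.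

The compounds shown have only methylsulfanyl or propyl at this place, leaving open how a longer chain such as butyl, an amine or a carboxylic acid would read there. Also open, going by these compounds, is whether the step would persist if the ethyl ester of the shared core gave way to a carboxylic acid.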